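From a Branched Chain to 3-Fluoropropyl

The source may report more compounds than this note shows. Statements on the series, on what has been measured and on what is new or still open speak of the compounds shown alone.

In a functional assay on HT-29 cells (Homo sapiens) for inhibition, read by luminescence and CellTiter-Glo, with a stated time of 24 h (a higher number here means that more compound is needed for the effect, a lower number that less compound is needed), compound 1 `CCCCn1nc(C(=O)N[C@H]2COc3ccccc3N(C)C2=S)nc1Cc1ccccc1` gives 510 nM, compound 2 `CCCCCn1nc(C(=O)N[C@H]2COc3ccccc3N(C)C2=S)nc1Cc1ccccc1` gives 805 nM and compound 3 `CC(C)Cn1nc(C(=O)N[C@H]2COc3ccccc3N(C)C2=S)nc1Cc1ccccc1` gives 1230 nM. Compound 3 stands clearly apart only from compound 1, as the measurements show a 2.4-fold higher number from compound 1 to compound 3 (0.38 log units; beyond the scatter). The other gap is small, with a 1.5-fold higher number from compound 2 to compound 3 (0.18 log units; within the scatter), and the remaining pair is equally close, with a 1.6-fold higher number from compound 1 to compound 2 (0.20 log units; within the scatter).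

Compound 4 `CN1C(=S)[C@@H](NC(=O)c2nc(Cc3ccccc3)n(CCCF)n2)COc2ccccc21` brings one change: 2-fluoroethyl in place of isopropyl on a saturated chain carbon bound to an aromatic nitrogen. In words, this is 2-fluoroethyl in place of isopropyl on a saturated chain carbon bound to an aromatic nitrogen. Cut one bond further out, it reads isobutyl to 3-fluoropropyl, so the branch of compound 3 is gone. The best guide is the step with a 2.4-fold higher number from compound 1 to compound 3 (0.38 log units; beyond the scatter), which compound 4 may partly reverse. Among the measured compounds shown here, no measured compound carries fluorine, so that part of the change has no guide in these data. A modest move to a lower number is therefore expected, estimated as a 1.9-fold lower number from compound 3 to compound 4 (0.28 log units; within the scatter). The estimate for compound 4 is 650 nM, with an expected range from 280 nM to 1400 nM.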

Compound 4, half-maximal effective concentration: 4760 nM
The estimate for compound 4 lay 7.3-fold (0.86 log units) below the measured number; the whole stated range lies below it.
By their numbers in this assay, from the lowest: compounds 1, 2 and 3 (each within the scatter of the next, the first and the last beyond it); then compound 4.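

Taking away the branch of compound 3 did not lower the number at this position: the step to 3-fluoropropyl gives a 3.9-fold higher number from compound 3 to compound 4 (0.59 log units; beyond the scatter) in this assay, so an unbranched chain alone does not keep the number low. The end of the chain matters too, since fluoro in place of methyl gives a 9.3-fold higher number from compound 1 to compound 4 (0.97 log units; beyond the scatter) and fluoro in place of ethyl gives a 5.9-fold higher number from compound 2 to compound 4 (0.77 log units; beyond the scatter) on a saturated chain carbon, three bonds along the chain from an aromatic nitrogen. Compound 4 therefore needs the most compound of the four, and each of its steps is larger than any step among the plain carbon chains.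

On these data alone, whether a hydroxyl, a methoxy or an amine at the end of this chain would raise the number in the same way stays open. Nothing measured here explains the rise.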